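Huh-7 cytotoxicity notes: carbamate tail and aryl exchange

This account rests on a few compounds, and the source may have more. Where it says the series, first, only, none or still open, it means among the compounds named here.

Compound 1 is `Nc1ccc(CN2N=C(c3ccc(F)cc3)C3C=CC=CC3C2=O)cc1`. Compound 2 is `CCCCOC(=O)Nc1ccc(CN2N=C(c3ccc(F)cc3)C3C=CC=CC3C2=O)cc1`; in an ADME assay on Huh-7 cells (Homo sapiens) for cytotoxicity, read by MTT assay, with a stated time of 48 h (on this read-out higher numbers stand for lower toxicity in this test and lower numbers for higher toxicity in this test), compound 2 gives 19500 nM. Compound 3 is `CN(C)CCCCOC(=O)Nc1ccc(Cn2nc(-c3ccncc3)c3ccccc3c2=O)cc1`; in this assay compound 3 gives 62700 nM. For compound 1, this assay reports > 80000 nM, which is a limit of the assay and not a number.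

Among the compounds with values here, the only one-place step measured is an at least 4.1-fold lower number from compound 1 to compound 2 (0.61 log units; beyond the scatter). Its reading is bounded by the limit of > 80000 nM in this assay, at which 1 of the 3 values shown sits. Within the data shown here, compound 3 holds the highest of the two numbers in this assay; compound 2 shows a lower one, and no single-place step joins them.

Compound 4 is `COc1ccc(-c2nn(Cc3ccc(NC(=O)OCCCCN(C)C)cc3)c(=O)c3ccccc23)cc1`. It differs from compound 3 in 4-methoxyphenyl in place of pyridin-4-yl on an aromatic carbon. Among the measured compounds shown here, no measured step touches this position; the one step in hand concerns the carbamate on the aniline nitrogen, which compound 3 and compound 4 share. With nothing that bears on the aryl exchange, no step beyond the scatter is expected in this assay, and the estimated change is a 1.4-fold lower number from compound 3 to compound 4 (0.14 log units; within the scatter). Compound 4 is expected to give about 45000 nM in this assay, within 15000 nM to 100000 nM.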

Compound 4, half-maximal cytotoxic concentration: 20300 nM
Estimate against measurement, compound 4: 2.2-fold (0.35 log units) above; the measured number falls inside the stated range.
By their numbers in this assay, from the lowest: compounds 2 and 4 (each within the scatter of the next); then compound 3. At a limit, above all of these: compound 1.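

The aryl group on the aromatic carbon next to the ring nitrogen is not a silent position in this assay: the exchange of pyridin-4-yl for 4-methoxyphenyl gives a 3.1-fold lower number from compound 3 to compound 4 (0.49 log units; beyond the scatter). Within the data shown here, this is the first measured step at this position, since the earlier one concerned only the butoxycarbonyl on a nitrogen on an aromatic ring, and here the carbamate tail stays the same on both sides of the step. Nothing in the data shown bears on why the number moves with this exchange.

Open, from the compounds shown here alone, is whether the step follows the methoxy group that enters or the ring nitrogen that leaves; an unsubstituted phenyl at this position would separate the two. Also open, going by these compounds, is whether the step holds with a longer chain in the carbamate tail.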